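Trifluoromethyl for methyl on a triazole amide series

A few compounds are considered here, and "the series" means these few. Any claim that something is new, unique, unknown or untested is made for them only; others in the source may bear on it.

Three compounds were measured in a functional assay on HT-29 cells (Homo sapiens) for cytotoxicity, read by MTT assay, with a stated time of 72 h; on this read-out lower numbers stand for stronger inhibition and higher numbers for weaker inhibition. Compound 1 `Cc1c(C(=O)Nc2ccc(Oc3ccnc4[nH]ccc34)c(F)c2)nnn1-c1ccc(F)c(Cl)c1` gives 1060 nM. Compound 3 `O=C(Nc1ccc(Oc2ccnc3[nH]ccc23)c(F)c1)c1nnn(-c2ccc(F)c(Cl)c2)c1C(F)(F)F` gives 630 nM, and the change between them, (trifluoromethyl in place of methyl on an aromatic carbon), made a 1.7-fold lower number from compound 1 to compound 3 (0.23 log units; within the scatter). Compound 2 `Cc1c(C(=O)Nc2ccc(Oc3ccnc4[nH]ccc34)cc2)nnn1-c1ccccc1F` gives 360 nM in this assay; how its core differs from that of compound 1 is not broken down here. Compound 4 `O=C(Nc1ccc(Oc2ccnc3[nH]ccc23)cc1)c1nnn(-c2ccccc2F)c1C(F)(F)F` is not yet measured. It differs from compound 2 by trifluoromethyl in place of methyl on an aromatic carbon, the same kind of change as that from compound 1 to compound 3, though here the ring atom bears a 2-fluorophenyl group where before it bore a 3-chloro-4-fluorophenyl group. Because the earlier step was a 1.7-fold lower number from compound 1 to compound 3 (0.23 log units; within the scatter), a step of similar size, a 1.6-fold lower number from compound 2 to compound 4 (0.19 log units; within the scatter), is expected from compound 2 to compound 4 in this assay. Compound 4 is therefore estimated at 230 nM, likely between 90 nM and 600 nM.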

Compound 4, half-maximal inhibitory concentration: 120 nM
The estimate for compound 4 lay 1.9-fold (0.28 log units) above the measured number, within the range that was stated.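

On the core of compound 2, trifluoromethyl in place of methyl gave a 3.0-fold lower number from compound 2 to compound 4 (0.48 log units; beyond the scatter) in this assay. The size of this step cannot be told apart from that of the step on the other core: the same change on two cores in this assay, a 1.7-fold lower number (0.23 log units; within the scatter) from compound 1 to compound 3 and a 3.0-fold lower number (0.48 log units; beyond the scatter) from compound 2 to compound 4, 1.8-fold (0.25 log units) apart, within the scatter of two such steps. So the change carried across these two cores with no clear difference in size, but only the step on the core of compound 2 stands beyond the scatter by itself, and two pairs show nothing about any further core.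

The two cores differ in more than one place, and the compounds shown do not separate those differences. They also leave open how other groups on that ring carbon, such as ethyl, chlorine or a nitrile, would compare.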